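This account rests on a few compounds, and the source may have more. Where it says the series, first, only, none or still open, it means among the compounds named here.

Compound 1 `CCCc1cc(=O)n([C@@H]2O[C@H](COP(=O)(O)OP(=O)(O)OP(=O)(O)O)[C@@H](O)[C@H]2O)c(=O)[nH]1` and compound 3 `CCCc1cc(=O)n([C@@H]2O[C@H](COP(=O)(O)OP(=O)(O)O)[C@@H](O)[C@H]2O)c(=O)[nH]1` share one core, while compound 2 `O=c1ccn([C@@H]2O[C@H](COP(=O)(O)OP(=O)(O)O)[C@@H](O)[C@H]2O)c(=S)[nH]1` and compound 4 `O=c1ccn([C@@H]2O[C@H](COP(=O)(O)O)[C@@H](O)[C@H]2O)c(=S)[nH]1` share another; the difference between the two cores is not broken down here. In an in vitro functional assay on 1321-N1 cells for agonist activity at P2Y purinoceptor 2 (Homo sapiens) (a higher number here means that more compound is needed for the effect, a lower number that less compound is needed), compound 1 gives > 1000 nM, which is a limit of the measurement and not a number. In this assay compound 3 gives > 100000 nM, again only a limit. The change from compound 1 to compound 3 is a hydrogen atom in place of a group of 4 heavy atoms (3 oxygen, 1 phosphorus; no ring), on an oxygen, and its step is a step that the two limits leave unreadable from compound 1 to compound 3. In this assay compound 2 gives > 1000 nM, likewise a limit. The change from compound 2 to compound 4 is the same one, (a hydrogen atom in place of a group of 4 heavy atoms (3 oxygen, 1 phosphorus; no ring), on an oxygen). For compound 4 a step that the limit leaves unreadable from compound 2 to compound 4 is expected, resting on compound 2 sitting at the limit of > 1000 nM in this assay, at which 2 of the 3 values shown sit, and compound 3 sitting at the limit of > 100000 nM in this assay, at which 1 of the 3 values shown sits. Compound 4 is therefore estimated at 100000 nM in this assay.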

Compound 4, half-maximal effective concentration: >= 100000 nM
Compound 4: only a limit was reported; the forecaster's own chance of this, stated with the estimate: 90%; the middle value lies on the limit itself.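

Compound 2 and compound 4 both give only limits in this assay, so no step can be read between them. The compounds shown leave open how far replacing this group with hydrogen shifts the half-maximal effective concentration on either core.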